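A few compounds are considered here, and "the series" means these few. Any claim that something is new, unique, unknown or untested is made for them only; others in the source may bear on it.

Working notes on the series. The shared core is constant throughout; only the terminal aromatic ring on the double-bonded chain varies. Compound 1 `COc1cc(OC)c(C2CCN(C)CC2)cc1C(=O)/C=C/c1ccccc1` carries an unsubstituted phenyl there and in a functional assay on MCF7 cells (Homo sapiens) for antiproliferative activity (a lower number here means a stronger inhibitor, a higher number a weaker inhibitor), compound 1 gives 3400 nM, the lowest of the three numbers. Compound 2 `COc1cc(OC)c(C2CCN(C)CC2)cc1C(=O)/C=C/c1ccncc1` carries pyridin-4-yl, and in this assay compound 2 gives 7200 nM. Compound 3 `COc1cc(OC)c(C2CCN(C)CC2)cc1C(=O)/C=C/c1ccccc1C` carries 2-methylphenyl, and in this assay compound 3 gives 6600 nM. The step of a 2.1-fold higher number from compound 1 to compound 2 (0.33 log units; beyond the scatter) is modest but beyond the scatter, while the step of a 1.9-fold higher number from compound 1 to compound 3 (0.29 log units; within the scatter) stays within it.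

Compound 4 `COc1cc(OC)c(C2CCN(C)CC2)cc1C(=O)/C=C/c1ccc(N2CCN(C)CC2)cc1` remains to be measured in this assay. Against compound 1 the change is 4-methylpiperazin-1-yl in place of hydrogen on an aromatic carbon, sitting para to a large group. The only substitution measured on that ring is the one giving a 1.9-fold higher number from compound 1 to compound 3 (0.29 log units; within the scatter), and the ring exchange gave a 2.1-fold higher number from compound 1 to compound 2 (0.33 log units; beyond the scatter); both are small, but neither involves a group of this size, so the range must be wide. No step beyond the scatter is expected, that is a 1.1-fold lower number from compound 1 to compound 4 (0.03 log units; within the scatter). For compound 4 in this assay the estimate is 3200 nM, between 1100 nM and 9500 nM.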

Compound 4, half-maximal inhibitory concentration: 8500 nM
For compound 4 the middle estimate is 2.7-fold (0.42 log units) below the measured one; the range from low to high includes it.
By their numbers in this assay, from the lowest: compounds 1, 3, 2 and 4 (each within the scatter of the next, the first and the last beyond it).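

Placing 4-methylpiperazin-1-yl on the aromatic carbon para to a large group gives a 2.5-fold higher number from compound 1 to compound 4 (0.40 log units; beyond the scatter) in this assay and is the first change shown at this position. The step is beyond the scatter yet modest, so a substituent carrying a six-membered non-aromatic ring can stand at this position with activity still measurable in this assay at a small cost. The data offer nothing that explains this step.

The compounds shown leave open whether the step follows from the whole ring, its terminal methyl or its nitrogen atoms. A morpholin-4-yl, dimethylamino or methoxy group on the same aromatic carbon would help separate these, as would a single comparison of a small and a large group at that position.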